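The source may report more compounds than this note shows. Statements on the series, on what has been measured and on what is new or still open speak of the compounds shown alone.

Values in an assay on HeLa cells for displacement of a labelled ligand from 5-hydroxytryptamine receptor 6 (Homo sapiens), with a stated time of 2 h; on this read-out higher numbers stand for weaker inhibition and lower numbers for stronger inhibition:
compound 1 `O=S(=O)(c1cccc(F)c1)c1cn(C2CCCNC2)c2ccccc12`, 6 nM
compound 2 `O=S(=O)(c1ccccc1)c1cn(C2CCNC2)c2ccccc12`, 5 nM
compound 3 `O=S(=O)(c1cccc(F)c1)c1cn(C2CCNC2)c2ccccc12`, 4.7 nM

Compound 3 gives the lowest of the three numbers, but its gaps to compound 2 and to compound 1 both lie within the scatter, so no ordering can be read from them. Compound 4 `O=S(=O)(c1cccc(F)c1)c1cn(C2CCNC2)c2cc(F)ccc12` differs from compound 3 by fluoro in place of hydrogen on an aromatic carbon. For the measured compounds named here, the only measured step of the same kind, a 1.1-fold lower number from compound 2 to compound 3 (0.03 log units; within the scatter), changed nothing beyond the scatter; there is no measured fluoro step on the ring in question. The ring change a 1.3-fold lower number from compound 1 to compound 3 (0.11 log units; within the scatter) was likewise flat. A step of a 1.0-fold lower number from compound 3 to compound 4 (0.02 log units; within the scatter) is therefore expected, not beyond the scatter in either direction. Compound 4 is estimated at 4.5 nM, range 1.5 nM to 13 nM.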

Compound 4, inhibition constant: 18 nM
Compound 4: middle estimate off by 4.0-fold (0.60 log units), on the low side, and the stated range ends below it.
By their numbers in this assay, from the lowest: compounds 3, 2 and 1 (each within the scatter of the next); then compound 4.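

In this assay, for the compounds shown here, fluoro in place of hydrogen on this aromatic carbon of the fused system, meta to a fused ring and para to a fused ring, gives a 3.8-fold higher number from compound 3 to compound 4 (0.58 log units; beyond the scatter), the first step beyond the scatter. The same kind of exchange at another place, a 1.1-fold lower number from compound 2 to compound 3 (0.03 log units; within the scatter), showed no readable change, so across these two steps the outcome of adding fluoro depends on where it stands.

As far as these compounds go, whether chloro, methoxy or an amine on this same carbon would shift the number as fluoro does remains open, as does the outcome of this fluoro on the piperidin-3-yl compound 1. Nothing available bears on the cause of this rise.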